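The source may report more compounds than this note shows. Statements on the series, on what has been measured and on what is new or still open speak of the compounds shown alone.

Compound 1, `COC(=O)c1ccc(-c2cn(CC(=O)Nc3nc(C)cs3)nn2)cc1`: in a functional assay on BMDM cells (Mus musculus, strain C57BL/6) for inhibition, with a stated time of 2 days (on this read-out lower numbers stand for stronger inhibition and higher numbers for weaker inhibition), compound 1 gives > 30000 nM, which is a limit of the assay rather than a number.
Compound 2, `C#Cc1ccc(-c2cn(CC(=O)Nc3cc(C)on3)nn2)cc1`: in this assay compound 2 gives > 30000 nM, again a limit.
Compound 3, `Cc1cc(NC(=O)Cn2cc(-c3ccc(F)cc3)nn2)no1`: in this assay compound 3 gives > 30000 nM, again a limit.

Compound 3 thus stands at the limit, and so do the two other measured compounds, a situation summed up by the limit of > 30000 nM in this assay, at which 3 of the 3 values shown sit. None of the three can be ranked against another. Compound 4, `COC(=O)c1ccc(-c2cn(CC(=O)Nc3cc(C)on3)nn2)cc1`, has not yet been measured. It differs from compound 3 at one place: methoxycarbonyl in place of fluoro on an aromatic carbon. Among the measured compounds shown here, the only measured step that touches the same aromatic carbon is a step that the two limits leave unreadable from compound 2 to compound 3, whose size the two limits leave unreadable. Compound 1 carries the same methoxycarbonyl group on a different core and also sits at the limit. For the measured compounds named here, no measured step therefore gives a readable size for a change in this assay, and no movement beyond the scatter can be predicted in either direction. Compound 4 is expected to remain at the limit, so the step of a number no higher from compound 3 to compound 4 (the limit leaves the size open) is expected to be none. Compound 4 is estimated at 30000 nM, with a range from 10000 nM to 100000 nM.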

Compound 4, half-maximal inhibitory concentration: > 30000 nM
Compound 4: no number, only a limit; the forecaster's own chance of this, stated with the estimate: 85%; the middle value sits exactly at the limit.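

Among the compounds shown here, compound 4 sits at a limit of the assay, not at a number, as do compound 1, compound 2 and compound 3, so no step from compound 4 to any of them can be read: the limit of > 30000 nM in this assay, at which 4 of the 4 values shown sit.

The compounds shown leave open whether changing the group on the aromatic carbon or on the amide-type nitrogen makes any difference in this assay.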